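A few compounds are considered here, and "the series" means these few. Any claim that something is new, unique, unknown or untested is made for them only; others in the source may bear on it.

Compound 1 `C#Cc1nc2ccccc2[se]1` carries an ethynyl group on a core that holds selenium. In a functional assay on NCI-H522 cells (Homo sapiens) for cytotoxicity, with a stated time of 3 days (on this read-out lower numbers stand for stronger inhibition and higher numbers for weaker inhibition), compound 1 gives 2170 nM. Compound 2 `Brc1nc2ccccc2[se]1` keeps the same core but carries bromo instead. In this assay compound 2 gives only a limit, > 40000 nM, which is not a number. The change that sets them apart is bromo in place of ethynyl on an aromatic carbon, and it made the step of an at least 18-fold higher number from compound 1 to compound 2 (1.26 log units; beyond the scatter), consistent with the limit of > 40000 nM in this assay, at which 1 of the 3 values shown sits.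

Compound 3 `C#Cc1nc2ccccc2o1` carries the ethynyl group on a core that holds oxygen rather than selenium; the difference between the two cores is not broken down here. In this assay compound 3 gives 1260 nM, a figure that sits within the usual scatter of the figure for compound 1.

Compound 4 `Brc1nc2ccccc2o1` is to compound 3 what compound 2 is to compound 1: the change is bromo in place of ethynyl on an aromatic carbon. For the measured compounds named here, it is the same kind of change as the one from compound 1 to compound 2, though the place differs, since here the bromo sits next to the ring oxygen where before it sat next to the ring selenium. Since the earlier step was large, compound 4 is expected to show a step of about a 24-fold higher number from compound 3 to compound 4 (1.38 log units; beyond the scatter). Compound 4 is therefore estimated at roughly 30000 nM, with a plausible range from 10000 nM to 90000 nM, and a real chance that only a limit is reported.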

Compound 4, half-maximal inhibitory concentration: > 40000 nM
Compound 4: a limit, no number; the forecaster's own chance of this, stated with the estimate: 55%; at least 1.3-fold (0.12 log units) between middle value and limit.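

Replacing ethynyl with bromo on the core that holds oxygen gave an at least 31-fold higher number from compound 3 to compound 4 (1.50 log units; beyond the scatter) in this assay, and the same replacement on the core that holds selenium moved the number in the same direction, so in these two pairs the change carries over from one core to the other: the same change on two cores in this assay, an at least 18-fold higher number (1.26 log units; beyond the scatter) from compound 1 to compound 2 and an at least 31-fold higher number (1.50 log units; beyond the scatter) from compound 3 to compound 4; the limit leaves it open whether they differ

Compound 4 gives > 40000 nM, which is a limit and not a number, and compound 2 ends at the same limit: the limit of > 40000 nM in this assay, at which 2 of the 4 values shown sit.

What this does not show is the true size of either step, so it cannot be said whether the swap costs more on one core than on the other, and two pairs of compounds make no general rule for other cores.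

The compounds shown leave open how other small groups in the same place would read, for instance chloro, an amine or a longer chain that ends in a triple bond. They also leave open whether the triple bond itself matters, a question that an ethyl group, with the same two carbons but no triple bond, could put to the test in this assay.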